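Returning a ring to the side chain of compound 2

A few compounds are considered here, and "the series" means these few. Any claim that something is new, unique, unknown or untested is made for them only; others in the source may bear on it.

Compound 2 `NCCNc1cc2c(cc1F)c(=O)c(C(=O)O)cn2Cc1ccc(-c2ccccc2)cc1` carries a (2-aminoethyl)amino group on the shared core. For the measured compounds named here, in an assay on isolated protein for inhibition of DNA topoisomerase 1 (Homo sapiens), with a stated time of 15 min (on this read-out lower numbers stand for stronger inhibition and higher numbers for weaker inhibition), compound 2 gives 72800 nM, the highest of the two numbers measured so far. Going by the values given here, its only neighbour is compound 1 `O=C(O)c1cn(Cc2ccc(-c3ccccc3)cc2)c2cc(N3CC4CNCC4C3)c(F)cc2c1=O`, which in this assay gives 33300 nM; the step of a 2.2-fold higher number from compound 1 to compound 2 (0.34 log units; beyond the scatter) replaced a larger two-ring group with the short chain and weakened inhibition modestly. Compound 3 `CNC[C@@H]1CCN(c2cc3c(cc2F)c(=O)c(C(=O)O)cn3Cc2ccc(-c3ccccc3)cc2)C1` differs from compound 2 in one place: 3-((methylamino)methyl)pyrrolidin-1-yl in place of (2-aminoethyl)amino on an aromatic carbon. This change restores a group of the same heavy-atom count as in compound 1, though with one ring instead of two, so it partly reverses the step that weakened compound 2. Among the compounds with values here, the only bearing step is the one from compound 1 to compound 2, so a modest shift back toward the number of compound 1 is expected, a 2.1-fold lower number from compound 2 to compound 3 (0.32 log units; beyond the scatter). Compound 3 is therefore estimated at 35000 nM, within a range from 12000 nM to 100000 nM.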

Compound 3, half-maximal inhibitory concentration: 168000 nM
Compound 3: middle estimate off by 4.8-fold (0.68 log units), on the low side; the measured number lies above the stated range.
By their numbers in this assay, from the lowest: compound 1; then compound 2; then compound 3.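

In this assay, returning a ring to this aromatic carbon does not recover inhibition: 3-((methylamino)methyl)pyrrolidin-1-yl in place of (2-aminoethyl)amino gives a 2.3-fold higher number from compound 2 to compound 3 (0.36 log units; beyond the scatter), so adding heavy atoms and a ring here does not by itself lower the number. Two groups with the same heavy-atom count also differ clearly, with a 5.0-fold higher number from compound 1 to compound 3 (0.70 log units; beyond the scatter), which shows that the one-ring group cannot stand in for the two-ring group of compound 1 at this position. Nothing measured here accounts for these differences.

The compounds shown leave open whether the weaker inhibition of compound 3 goes with its single ring, its methylamino end or its defined stereocentre. The same ring carrying an aminomethyl group, or the mirror-image form of compound 3, would begin to separate these possibilities.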